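From Fluoro to Methyl on an Aromatic Carbon

The source may report more compounds than this note shows. Statements on the series, on what has been measured and on what is new or still open speak of the compounds shown alone.

In a functional assay on P388 cells (Mus musculus) for inhibition (on this read-out lower numbers stand for stronger inhibition and higher numbers for weaker inhibition), compound 1 `O=C1/C(=C/c2ccc(F)cc2)Cc2ccccc21` gives > 50000 nM. That value is a limit of the assay and not a number. Going by the values given here, compound 2 `Cc1cccc(/C=C2\Cc3ccccc3C2=O)c1` gives 24900 nM, the only actual number so far. Compound 3 `Cc1ccc(/C=C2\Cc3ccccc3C2=O)cc1` differs from compound 1 in one place: methyl in place of fluoro on an aromatic carbon, with methyl in place of fluoro on an aromatic carbon. The expectation rests on compound 2 at 24900 nM, which also carries a methyl. The expected step of an at least 1.7-fold lower number from compound 1 to compound 3 (0.25 log units; that floor lies within the scatter) is modest, towards stronger inhibition. For compound 3 the estimated value is 28000 nM, with an expected range of 12000 nM to 50000 nM.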

Compound 3, half-maximal inhibitory concentration: 38600 nM
For compound 3 the middle estimate is 1.4-fold (0.14 log units) below the measured one, within the range that was stated.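

On an aromatic carbon para to a large group, methyl in place of fluoro gives an at least 1.2-fold lower number from compound 1 to compound 3 (0.11 log units; that floor lies within the scatter), and compound 3 puts an actual number on this position at 38600 nM. In this assay compound 1 gives > 50000 nM, which is a limit of the assay and not a number. The step is therefore only a floor, and its full size cannot be read because compound 1 sits at that limit: the limit of > 50000 nM in this assay, at which 1 of the 3 values shown sits.

On these data alone, whether this change moves inhibition beyond the usual scatter stays open. So does how an amine or a carboxylic acid on this same aromatic carbon would read.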